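Cytotoxicity notes: from compound 3 to compound 4

A few compounds are considered here, and "the series" means these few. Any claim that something is new, unique, unknown or untested is made for them only; others in the source may bear on it.

compound 1 `O=C1c2ccccc2NS(=O)(=O)N1COCCO`: 160 ug/mL
compound 2 `O=C1c2ccccc2NS(=O)(=O)N1Cc1ccccc1`: > 50 ug/mL
compound 3 `CC(=O)OCCOCN1C(=O)c2ccccc2NS1(=O)=O`: > 200 ug/mL

Going by the values given here, in a functional assay on HEL cells (Homo sapiens) (a lower number here means that less compound is tolerated, a higher number that more compound is tolerated), compound 1 gives 160 ug/mL, the only read number in the set. For compound 2 this assay reports only a limit, > 50 ug/mL. For compound 3 it likewise reports only a limit, > 200 ug/mL, so compound 3 stands at the upper edge of what is shown, tolerated at least as well as any other compound here, with no exact number known (the limit of > 200 ug/mL in this assay, at which 1 of the 3 values shown sits; (the limit of > 50 ug/mL in this assay, at which 1 of the 3 values shown sits)).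

Compound 4 `C#CCOCN1C(=O)c2ccccc2NS1(=O)=O` differs from compound 3 by ethynyl in place of acetoxymethyl on a saturated chain carbon bound to an oxygen on a saturated carbon. Of the measured steps, only an at least 1.2-fold higher number from compound 1 to compound 3 (0.09 log units; that floor lies within the scatter) carries a readable floor, and it concerns a different change; a step that the limit leaves unreadable from compound 1 to compound 2 and a step that the two limits leave unreadable from compound 2 to compound 3 cannot be sized. Nothing measured speaks to the ethynyl in place of acetoxymethyl directly. The step of an at least 1.3-fold lower number from compound 3 to compound 4 (0.12 log units; that floor lies within the scatter) is therefore expected to stay roughly within the scatter, possibly a small drop from the limit. Compound 4 is estimated at 150 ug/mL, within 60 ug/mL to 250 ug/mL, with a fair chance that this assay again reports only a limit.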

Compound 4, half-maximal cytotoxic concentration: 169 ug/mL
Compound 4: the middle estimate sits 1.1-fold (0.05 log units) below what was measured; low and high end bracket the measured number.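

With compound 4, the side chain carries a second read number in this assay. Ethynyl in place of hydroxymethyl on a saturated chain carbon bound to an oxygen on a saturated carbon gives a 1.1-fold higher number from compound 1 to compound 4 (0.02 log units; within the scatter) and is the first step here with both ends read. Ethynyl in place of acetoxymethyl at that place gives an at least 1.1-fold lower number from compound 3 to compound 4 (0.07 log units; that floor lies within the scatter) as a floor only, and the step to compound 4 from compound 2 cannot be read; the value of compound 3 is a limit: the limit of > 200 ug/mL in this assay, at which 1 of the 4 values shown sits.

On these data alone, how far compound 4 truly lies from compound 3 stays open, as does any comparison with the benzyl-type group of compound 2. Also open, as far as these compounds go, is whether an amine, a carboxylic acid or a longer chain at this place would move the number beyond the scatter.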